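A few compounds are considered here, and "the series" means these few. Any claim that something is new, unique, unknown or untested is made for them only; others in the source may bear on it.

In a functional assay on HL-60 cells (Homo sapiens) for antiproliferative activity, read by MTT assay, with a stated time of 48 h (a higher number here means a weaker inhibitor, a lower number a stronger inhibitor), the measured compounds gave these values:

compound 1 `CC(=O)OC/C1=C/C[C@](C)(CCC=C(C)C)/C=C/[C@@H](OC(=O)C=C(C)C)[C@](C)(O)/C=C/C1=O` gives 2950 nM
compound 2 `CC(C)=CCC[C@]1(C)/C=C/[C@@H](OC(=O)C=C(C)C)[C@](C)(O)/C=C/C(=O)/C(CN(C)C)=C\C1` gives 140 nM
compound 3 `CC(C)=CCC[C@]1(C)/C=C/[C@@H](OC(=O)C=C(C)C)[C@](C)(O)/C=C/C(=O)/C(CN(C(C)C)C(C)C)=C\C1` gives 740 nM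

Compound 3 holds the middle place of the three numbers, with a modest step down to it (a 4.0-fold lower number from compound 1 to compound 3 (0.60 log units; beyond the scatter)) and a modest step up to it (a 5.3-fold higher number from compound 2 to compound 3 (0.72 log units; beyond the scatter)).

Compound 4 `CC(C)=CCC[C@]1(C)/C=C/[C@@H](OC(=O)C=C(C)C)[C@](C)(O)/C=C/C(=O)/C(COC(=O)c2ccc([N+](=O)[O-])cc2)=C\C1` is still unmeasured. It carries ((4-nitrophenyl)carbonyl)oxy in place of diisopropylamino on a saturated chain carbon bound to a double-bonded ring carbon and, like compound 1, has an ester at this place rather than an amino group. Swapping acetoxy for an amino group lowered the number both times, by a large step (a 21-fold lower number from compound 1 to compound 2 (1.32 log units; beyond the scatter)) and by a modest one (a 4.0-fold lower number from compound 1 to compound 3 (0.60 log units; beyond the scatter)). Leaving the amino series should therefore reverse part of that gain, although no measured compound carries an aromatic ester. A modest step to a higher number is expected in this assay (a 2.0-fold higher number from compound 3 to compound 4 (0.31 log units; beyond the scatter)). For compound 4 the estimated value is 1500 nM, with an expected range from 400 nM to 5000 nM.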

Compound 4, half-maximal inhibitory concentration: 830 nM
Estimate against measurement, compound 4: 1.8-fold (0.26 log units) above, within the range that was stated.
By their numbers in this assay, from the lowest: compound 2; then compounds 3 and 4 (each within the scatter of the next); then compound 1.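

At this position, an amino group is not needed to lower the number in this assay: an ester can match diisopropylamino, with a 1.1-fold higher number from compound 3 to compound 4 (0.05 log units; within the scatter). The ester group itself also matters, as 4-nitrophenyl in place of methyl on a carbonyl carbon gives a 3.6-fold lower number from compound 1 to compound 4 (0.55 log units; beyond the scatter), so esters at this place do not all behave alike. Dimethylamino remains apart from the aromatic ester, with a 5.9-fold higher number from compound 2 to compound 4 (0.77 log units; beyond the scatter), which shows that the lowest number among these compounds goes with this one small amine and not with amino groups or aromatic esters in general.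

As far as these compounds go, whether an unsubstituted benzoyl ester, a morpholine or a carboxylic acid at this place would give a similar number remains open. Nothing given here explains why these groups differ or why diisopropylamino and the aromatic ester fall so close together.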